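The source may report more compounds than this note shows. Statements on the series, on what has been measured and on what is new or still open speak of the compounds shown alone.

Working notes on the series.

Compound 1, `COc1ccc(CNc2nc3cc(N)cc(N)c3nc2-c2ccccc2)cc1OC`, is the reference point. For the measured compounds named here, in a functional assay on OVCAR-4 cells (Homo sapiens) for inhibition, read by sulforhodamine B assay, with a stated time of 48 h (a higher number here means that more compound is tolerated, a lower number that less compound is tolerated), compound 1 gives 52500 nM, and this is the only plain number in hand for the series. Compound 2, `CCOC(=O)[C@H](CCC(=O)O)NC(=O)c1ccc(Sc2nc3cc(N)cc(N)c3nc2-c2ccccc2)cc1`, belongs to the same core with a different substituent. In this assay compound 2 gives < 100000 nM, which is a limit of the assay and not a number. So compound 1 stands as the single measured value, with the limit of < 100000 nM in this assay, at which 1 of the 2 values shown sits, being the only other entry, and no step between measured compounds can be drawn.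

Compound 3, `COc1ccc(CNc2nc3cc(N)cc(N)c3nc2-c2ccccc2)cc1`, follows from compound 1 by hydrogen in place of methoxy on an aromatic carbon, leaving a single methoxy on that ring. Going by the values given here, with no measured step for a comparable change, the expected step from compound 1 to compound 3 is a 1.0-fold higher number from compound 1 to compound 3 (0.02 log units; within the scatter), which is not expected to go beyond the usual scatter in either direction. On that basis compound 3 is estimated at 55000 nM in this assay, with a range from 25000 nM to 100000 nM, noting that a reading at the assay limit would remain possible.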

Compound 3, concentration lethal to 50% of the cells: 47900 nM
The estimate for compound 3 lay 1.1-fold (0.06 log units) above the measured number; the measured number falls inside the stated range.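

In this assay, for the compounds shown here, the series now has its first readable step, a 1.1-fold lower number from compound 1 to compound 3 (0.04 log units; within the scatter), and it is the only step that can be read so far. At this position, ortho to a methoxy group and meta to a large group, hydrogen and methoxy therefore cannot be told apart in this read-out, and the 3,4-dimethoxyphenyl and 4-methoxyphenyl groups stand level within the scatter. Nothing in hand bears on why this change leaves the number in place.

This single step leaves open whether another group at the same position, such as a hydroxyl, an amine or a longer alkoxy chain, would move the number beyond the scatter, and whether loss of the remaining methoxy, giving a plain phenyl, would do so. The entry for compound 2 is a limit of the assay and not a number, so its steps to the other compounds cannot be read.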